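This account rests on a few compounds, and the source may have more. Where it says the series, first, only, none or still open, it means among the compounds named here.

For the measured compounds named here, compound 1 `O=C(O)COC(=O)N(C1CC1)[C@H]1c2ccccc2N(C(=O)c2cccc(F)c2)[C@H]2CC[C@H]21` is the stronger of the two measured members: in a functional assay on cells for antagonist activity at prostaglandin D2 receptor 2 (Homo sapiens), read by chemiluminescence and beta-arrestin recruitment, with stated times of 30 min and 60 min (a lower number here means a stronger inhibitor, a higher number a weaker inhibitor), compound 1 gives 1.1 nM, the lowest of the two numbers in hand. Going by the values given here, its nearest neighbour, compound 2 `O=C(O)CCC(=O)N(C1CC1)[C@H]1c2ccccc2N(C(=O)c2cccc(F)c2)[C@H]2CC[C@H]21`, gives 9.3 nM in this assay, and the single measured step, an 8.5-fold higher number from compound 1 to compound 2 (0.93 log units; beyond the scatter), concerns only the acid-bearing arm on the carbonyl carbon.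

Compound 3 `O=C(O)COC(=O)N(C1CC1)[C@H]1c2ccccc2N(C(=O)c2ccc(OC(F)(F)F)cc2)[C@H]2CC[C@H]21` alters a different part of compound 1: 4-(trifluoromethoxy)phenyl in place of 3-fluorophenyl on a carbonyl carbon, on a carbonyl carbon whose other neighbours are an amide-type nitrogen in a ring. Among the compounds with values here, no measured step touches this aromatic group, so the step from compound 1 to compound 2 gives no direct guide; it only shows that the series can move well beyond the scatter with a single change. For compound 3 a step in this assay of a 2.0-fold higher number from compound 1 to compound 3 (0.30 log units; within the scatter) is expected, in the direction of a somewhat higher number but possibly within the scatter. The estimate for compound 3 in this assay is 2.2 nM, with a range from 0.6 nM to 9 nM.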

Compound 3, half-maximal inhibitory concentration: 1.4 nM
Compound 3: the middle estimate sits 1.6-fold (0.20 log units) above what was measured; the measured number falls inside the stated range.
By their numbers in this assay, from the lowest: compounds 1 and 3 (each within the scatter of the next); then compound 2.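

On the carbonyl carbon whose other neighbours are an amide-type nitrogen in a ring, 4-(trifluoromethoxy)phenyl, with 11 heavy atoms, replaces 3-fluorophenyl, with 7, and this assay gives a 1.3-fold higher number from compound 1 to compound 3 (0.10 log units; within the scatter). This position therefore accepts this larger aromatic group without a change beyond the scatter, whereas the change in the acid-bearing arm gives an 8.5-fold higher number from compound 1 to compound 2 (0.93 log units; beyond the scatter). No supporting measurement bears on why the aromatic change leaves the number within the scatter.

Still open, on these data alone, is whether this tolerance extends to aromatic groups carrying an amine or a carboxylic acid, which would test a charged group at this position. Also open is how 4-(trifluoromethoxy)phenyl behaves alongside the 2-carboxyethyl arm, since the two changes are shown only separately.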